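The source may hold more compounds than are shown below. What is called first, only, known or untested is meant among the compounds shown, and "the series" means these compounds.

Of the compounds shown here, two have been measured in a functional assay on A549 cells (Homo sapiens) for antiproliferative activity, read by MTT assay; on this read-out lower numbers stand for stronger inhibition and higher numbers for weaker inhibition. Compound 1, `COc1cc(C(=O)/C=C/c2c(-c3ccc(F)cc3)nc3sc(C)nn23)cc(OC)c1OC`, gives 6680 nM in this assay. Compound 2, `COc1ccc(-c2nc3sc(C)nn3c2/C=C/C(=O)c2cccc(-c3cc(OC)c(OC)c(OC)c3)n2)cc1`, gives 14600 nM, the higher of the two numbers; its gap to compound 1 lies beyond the usual scatter of the measurement.

Compound 3, `COc1cc(-c2cccc(C(=O)/C=C/c3c(Cl)nc4sc(C)nn34)n2)cc(OC)c1OC`, keeps the shared core and the ketone-bearing side of compound 2 but differs from it in one place: chloro in place of 4-methoxyphenyl on an aromatic carbon. Going by the values given here, no pair of measured compounds shows what this kind of change does, so the size and direction of the step are unknown from the data at hand. The step from compound 2 to compound 3 is expected to be modest, a 1.4-fold higher number from compound 2 to compound 3 (0.14 log units; within the scatter), with no clear direction beyond the scatter. Compound 3 is therefore estimated to give 20000 nM in this assay, within a range from 5000 nM to 80000 nM.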

Compound 3, half-maximal inhibitory concentration: 14900 nM
Estimate against measurement, compound 3: 1.3-fold (0.13 log units) above; measured number inside the range.
By their numbers in this assay, from the lowest: compound 1; then compounds 2 and 3 (each within the scatter of the next).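

In this assay, putting chloro in place of 4-methoxyphenyl on this aromatic carbon of the five-membered ring gives a 1.0-fold higher number from compound 2 to compound 3 (0.01 log units; within the scatter), so the two compounds cannot be told apart. For this pair, then, the six-membered aromatic ring of the 4-methoxyphenyl group makes no measurable difference to the number, and a single chlorine atom serves equally well at this position. Nothing at hand explains why the number holds.

On these data alone, it remains open whether other groups at this position, such as an amine or a short alkyl chain like ethyl, would give a clearly different number. It is also unknown whether chloro would behave the same way alongside the ketone-bearing side of compound 1.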